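Ester variation on the shared core of the nitroanilide series

The compounds below may be only part of what the source reports. "The series", "measured", "known", "first", "only" and "open" are said of these compounds alone.

Measured compounds in a functional assay on HepG2 cells (Homo sapiens) for inhibition, read by MTT assay, with a stated time of 72 h; on this read-out higher numbers stand for weaker inhibition and lower numbers for stronger inhibition:
compound 1 `COc1ccc(C(=O)OC2(C(=O)Nc3ccc([N+](=O)[O-])cc3)CCCCC2)cc1` gives 57.1 nM
compound 2 `O=C(OC1(C(=O)Nc2ccc([N+](=O)[O-])cc2)CCCCC1)c1ccc([N+](=O)[O-])cc1` gives 14.1 nM
compound 3 `CCOC(=O)c1ccccc1C(=O)OC1(C(=O)Nc2ccc([N+](=O)[O-])cc2)CCCCC1` gives 517 nM

Among the compounds with values here, compound 2 holds the lowest number of the three in this assay; compound 1 sits nearest and compound 3 furthest, with a 4.0-fold lower number from compound 1 to compound 2 (0.61 log units; beyond the scatter) the only single-point step among them. The next change is ethyl in place of 4-nitrophenyl on a carbonyl carbon, giving compound 4 `CCC(=O)OC1(C(=O)Nc2ccc([N+](=O)[O-])cc2)CCCCC1`. Within the data shown here, no measured step removes the aromatic ring of the ester; the available steps only vary what sits on that ring, and they show that this part of the molecule moves the number: compound 1 against compound 2 is a modest step, while compound 3 against compound 2 is a large gap. Taking the whole 4-nitrophenyl away is a larger change than either, so a weaker result than compound 2 is expected, of a size taken as an 11-fold higher number from compound 2 to compound 4 (1.03 log units; beyond the scatter). Compound 4 is accordingly estimated at 150 nM, with a range of 30 nM to 800 nM.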

Compound 4, half-maximal inhibitory concentration: 21.5 nM
The estimate for compound 4 lay 7.0-fold (0.84 log units) above the measured number, outside the stated range (below it).
By their numbers in this assay, from the lowest: compounds 2 and 4 (each within the scatter of the next); then compound 1; then compound 3.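

In this assay the aromatic ring of the ester proves unnecessary for a low number: ethyl in place of 4-nitrophenyl on a carbonyl carbon leaves compounds 2 and 4 indistinguishable (a 1.5-fold higher number from compound 2 to compound 4 (0.18 log units; within the scatter)). Ethyl also compares favourably with 4-methoxyphenyl at the same place (a 2.7-fold lower number from compound 1 to compound 4 (0.42 log units; beyond the scatter)), so among compounds 1, 2 and 4 the ring brings no gain over ethyl, and what it carries decides whether it matches ethyl or falls short. No supporting measurement is available to explain this behaviour of the position.

Open, on these data alone, is whether a longer chain such as butyl, or a chain ending in an amine or a carboxylic acid, keeps the number at this carbonyl carbon. Also open, as far as these compounds go, is how a saturated ring such as cyclohexyl compares with ethyl there.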